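The source may hold more compounds than are shown below. What is called first, only, known or untested is meant among the compounds shown, and "the series" means these compounds.

Measured so far:
compound 1 `Cc1cccc(Nc2ncnc3ccc(NC(=S)NCc4ccccc4)cc23)c1` — 19500 nM
compound 2 `S=C(Nc1ccccc1)Nc1ccc2ncnc(Nc3cccc(Br)c3)c2c1` — 10000 nM

In a functional assay on MDA-MB-231 cells (Homo sapiens) for inhibition, read by MTT assay, with a stated time of 48 h (a lower number here means a stronger inhibitor of growth, a higher number a weaker inhibitor of growth), compound 2 gives 10000 nM, and compound 1 gives 19500 nM in this assay; the two numbers lie within the scatter of each other, so no order between them can be read. Compound 2 is the one from which the next step is taken. Compound 3 `CNC(=S)Nc1ccc2ncnc(Nc3cccc(Br)c3)c2c1` has not yet been measured in this assay. It differs from compound 2 in one place: methyl in place of phenyl on an amide-type nitrogen. Going by the values given here, no measured pair shows the effect of such a change, so the size and direction of the step rest on expectation alone. A step toward a higher number is expected, of moderate size and possibly not beyond the scatter, with the step from compound 2 to compound 3 estimated as a 2.0-fold higher number from compound 2 to compound 3 (0.30 log units; within the scatter). For compound 3 the expected value in this assay is 20000 nM, in a range from 6000 nM to 60000 nM.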

Compound 3, concentration for 50% growth inhibition: > 30000 nM
Compound 3: only a limit was reported (the forecaster's own chance of this, stated with the estimate: 15%); middle value at least 1.5-fold (0.17 log units) away from the limit.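

In this assay compound 3 gives > 30000 nM, which is a limit of the assay and not a number. Methyl in place of phenyl on the amide-type nitrogen gives an at least 3.0-fold higher number from compound 2 to compound 3 (0.47 log units; beyond the scatter), and this lower bound alone lies beyond the scatter, although the true size of the step stays unknown: the limit of > 30000 nM in this assay, at which 1 of the 3 values shown sits.

Going by these compounds alone, compound 1 and compound 2 differ in more than one place and offered no such step, so this is the first sign that the group on this nitrogen matters.

The compounds shown leave open whether the ring itself or simply the number of carbons on this nitrogen counts. A cyclohexyl group or a longer chain such as butyl at this place would separate the two readings.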